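A few compounds are considered here, and "the series" means these few. Any claim that something is new, unique, unknown or untested is made for them only; others in the source may bear on it.

Working notes on the series.

Two compounds of the shared core carry numbers in a functional assay on PC-12 cells (Rattus norvegicus) for cytotoxicity, read by MTT assay, with stated times of 2 h and 24 h, tested at 5 uM; on this read-out lower numbers stand for a weaker effect and higher numbers for a stronger effect at the one concentration tested. Compound 1 `Cc1ccc(-n2nc(-c3ccc(C(F)(F)F)cc3O)nc2-c2ccccc2O)cc1` gives 94.1% in this assay. Compound 2 `Oc1cc(C(F)(F)F)ccc1-c1nc(-c2ccccc2O)n(-c2ccc(Br)cc2)n1` gives 89.8% in this assay. Within the data shown here, the single step between them, bromo in place of methyl on an aromatic carbon, is a number 4.3 percentage points lower from compound 1 to compound 2 (within the scatter), so compound 2 stands with compound 1 inside the scatter, and neither can be called the stronger or weaker of the pair.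

Compound 3 `Oc1cc(C(F)(F)F)ccc1-c1nc(-c2ccccc2O)n(-c2cccc(Cl)c2)n1` is not yet measured in this assay. Its change from compound 2 is 3-chlorophenyl in place of 4-bromophenyl on an aromatic nitrogen. Among the measured compounds shown here, the only measured step that bears on it is the one at the same aromatic ring on the aromatic nitrogen, the change of the substituent from methyl to bromo, which was a number 4.3 percentage points lower from compound 1 to compound 2 (within the scatter); a shift of a halogen from one position to another of that ring has no measured counterpart here. Both measured compounds sit high in this assay, so the step from compound 2 to compound 3 is expected to be a number 1.8 percentage points lower from compound 2 to compound 3 (within the scatter), none beyond the scatter. For compound 3 the estimate in this assay is 88%, with a range from 75% to 98%.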

Compound 3, a percentage reported as activity, at one concentration (the size of the read-out at that concentration, not a potency): 92.7%
Compound 3: the middle estimate sits 4.7 percentage points below what was measured, and the stated range covers the measured number.
By their numbers in this assay, from the lowest: compounds 2, 3 and 1 (each within the scatter of the next).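

In this assay the step reads a number 2.9 percentage points higher from compound 2 to compound 3 (within the scatter) and the comparison with the methyl compound reads a number 1.4 percentage points lower from compound 1 to compound 3 (within the scatter) so 4-methylphenyl, 4-bromophenyl and 3-chlorophenyl on the aromatic nitrogen cannot be told apart at the one concentration tested. The earlier step changed only the substituent on this ring, whereas this step changes both the halogen and its place on the ring, and the number still stays within the scatter of the other two compounds. The two changes are joined in one step, so the result cannot assign any share to either, and no measurement bearing on a reason for the flat read-out is available.

All three compounds read high, so what the compounds shown leave open is whether any group on this ring can bring the number down, which a ring carrying an amine, a carboxylic acid or a longer chain in place of the halogen would address. A 4-chlorophenyl group would separate the exchange of halogen from the shift of its place, and a single concentration leaves potency across the series unresolved.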